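The source may report more compounds than this note shows. Statements on the series, on what has been measured and on what is new or still open speak of the compounds shown alone.

The compounds measured so far:
compound 1 `COc1ccc2c(=O)c(/C=C/C(=O)Nc3ccccc3)coc2c1` gives 51000 nM in a functional assay on A549 cells (Homo sapiens) for inhibition, read by MTT assay, with a stated time of 48 h; on this read-out higher numbers stand for weaker inhibition and lower numbers for stronger inhibition.
compound 2 `Cc1ccccc1NC(=O)/C=C/c1coc2cc(O)ccc2c1=O` gives > 100000 nM in this assay, which is a limit of the assay and not a number.
compound 3 `COc1ccc(CNC(=O)/C=C/c2coc3cc(OC)ccc3c2=O)cc1` gives 22500 nM in this assay.

Compound 3 stands at the lowest of the two numbers recorded; its nearest neighbour is compound 1, and the step of a 2.3-fold lower number from compound 1 to compound 3 (0.36 log units; beyond the scatter) came from 4-methoxybenzyl in place of phenyl on an amide-type nitrogen. Compound 2 sits at the limit of > 100000 nM in this assay, at which 1 of the 3 values shown sits, and contributes no number.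

Compound 4 `COc1ccc2c(=O)c(/C=C/C(=O)Nc3ccc(F)cc3)coc2c1` differs from compound 3 by 4-fluorophenyl in place of 4-methoxybenzyl on an amide-type nitrogen. For the measured compounds named here, the one measured step that bears on this is a 2.3-fold lower number from compound 1 to compound 3 (0.36 log units; beyond the scatter), and it runs in the opposite sense: placing 4-methoxybenzyl on the amide-type nitrogen lowered the number modestly. Taking it away again and putting 4-fluorophenyl there is expected to send the number back up by a similar modest amount, toward compound 1; the fluorine itself has no precedent among these compounds. Compound 4 is therefore expected to give 45000 nM in this assay, within 20000 nM to 100000 nM. The step of a 2.0-fold higher number from compound 3 to compound 4 (0.30 log units; within the scatter) is expected to be modest.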

Compound 4, half-maximal inhibitory concentration: 26800 nM
The estimate for compound 4 lay 1.7-fold (0.23 log units) above the measured number, within the range that was stated.
By their numbers in this assay, from the lowest: compounds 3, 4 and 1 (each within the scatter of the next, the first and the last beyond it). At a limit, above all of these: compound 2.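

In this assay, 4-fluorophenyl in place of 4-methoxybenzyl on the amide-type nitrogen came to a 1.2-fold higher number from compound 3 to compound 4 (0.08 log units; within the scatter) and so does not separate the two compounds. Fluoro in place of hydrogen on an aromatic carbon came to a 1.9-fold lower number from compound 1 to compound 4 (0.28 log units; within the scatter) and so leaves compound 4 unresolved from compound 1 as well, even though a 2.3-fold lower number from compound 1 to compound 3 (0.36 log units; beyond the scatter) sets those two apart, which means the lower number of compound 3 is not shown to belong to 4-methoxybenzyl alone. No measurement at hand bears on the reason for these steps.

As far as these compounds go, it stays open whether an amine, a carboxylic acid or a longer chain on the amide-type nitrogen would move the number beyond the scatter. Also open, from the compounds shown here alone, is whether chloro or trifluoromethyl in place of the fluoro would do so.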